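The source may report more compounds than this note shows. Statements on the series, on what has been measured and on what is new or still open speak of the compounds shown alone.

Measured in a functional assay on HOS cells (Homo sapiens) for antiproliferative activity, with a stated time of 72 h; a higher number here means a weaker inhibitor, a lower number a stronger inhibitor:
- compound 1 `OC[C@H]1O[C@@H](n2cnc3c(NCc4cccc(F)c4)ncnc32)[C@H](O)[C@@H]1O`: > 166000 nM, a limit
- compound 2 `OC[C@H]1O[C@@H](n2cnc3c(NCc4ccccc4Cl)ncnc32)[C@H](O)[C@@H]1O`: > 166000 nM, a limit

Compound 2 has no numerical value, only the limit > 166000 nM. The next compound is compound 3 `OC[C@H]1O[C@@H](n2cnc3c(NCc4ccccc4Br)ncnc32)[C@H](O)[C@@H]1O`, with the change bromo in place of chloro on an aromatic carbon, ortho to a large group.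

Within the data shown here, the one measured step that bears on this change is a step that the two limits leave unreadable from compound 1 to compound 2, and it has no readable size. Among the measured compounds shown here, the series so far stands at the limit of > 166000 nM in this assay, at which 2 of the 2 values shown sit. Nothing therefore points to a direction in this assay, and no step beyond the scatter is expected. Compound 3 will most likely also be reported only as a limit. The expected change is a step that the limit leaves unreadable from compound 2 to compound 3. For compound 3 the estimated value is 170000 nM, with an expected range of 90000 nM to 300000 nM.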

Compound 3, half-maximal inhibitory concentration: > 166000 nM
Compound 3 ended at the assay's limit; the forecaster's own chance of this, stated with the estimate: 80%; the middle value does not contradict the limit.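

In this assay compound 3 gives > 166000 nM as a limit and not a number. The steps linking compound 1, compound 2 and compound 3 therefore cannot be read, and the series stays here: the limit of > 166000 nM in this assay, at which 3 of the 3 values shown sit. The compounds shown leave open whether any benzyl variant on the shared core gives a measurable value in this assay.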